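Removing one methoxy group from a dimethoxyphenyl series

The source may report more compounds than this note shows. Statements on the series, on what has been measured and on what is new or still open speak of the compounds shown alone.

Compound 1 has the structure `Nc1cc(N)c2nc(-c3ccccc3)c(NCc3ccc(Cl)c(Cl)c3)nc2c1`. In a functional assay on CCRF-CEM cells (Homo sapiens) for inhibition, read by sulforhodamine B assay, with a stated time of 48 h (a higher number here means that more compound is tolerated, a lower number that less compound is tolerated), compound 1 gives 17400 nM. Compound 2 has the structure `COc1ccc(CNc2nc3cc(N)cc(N)c3nc2-c2ccccc2)cc1OC`, with a 3,4-dimethoxyphenyl in place of the 3,4-dichlorophenyl of compound 1. For compound 2 this assay reports only a limit, < 100000 nM, not a number. The step that the limit leaves unreadable from compound 1 to compound 2 is therefore unreadable, and compound 2 stands only as a limit among the values shown, (the limit of < 100000 nM in this assay, at which 1 of the 2 values shown sits). Compound 3, with the structure `COc1ccc(CNc2nc3cc(N)cc(N)c3nc2-c2ccccc2)cc1`, differs from compound 2 by hydrogen in place of methoxy on an aromatic carbon. No measured step concerns the removal of a methoxy group, and the one step shown is itself unreadable, so no direction beyond the scatter can be expected. The estimate for compound 3 in this assay is 40000 nM, within 8000 nM to 100000 nM. The expected step that goes with this estimate is a step that the limit leaves unreadable from compound 2 to compound 3.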

Compound 3, concentration lethal to 50% of the cells: < 100000 nM
Compound 3 gave a limit, no number; the forecaster's own chance of this, stated with the estimate: 40%; the middle value lies beyond the limit too.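

In this assay compound 3 gives only a limit, so its steps from compound 2 and from compound 1 cannot be read: the limit of < 100000 nM in this assay, at which 2 of the 3 values shown sit.

The compounds shown leave open whether hydrogen in place of methoxy changes the tolerated concentration at all, in either direction.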